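Aryl swap on the shared core: outlook for compound 3

This account rests on a few compounds, and the source may have more. Where it says the series, first, only, none or still open, it means among the compounds named here.

Measured compounds:
compound 1 `O=C(CCCCC1CCSS1)NCc1cn(CCCCCOc2ccc3ccc(=O)oc3c2)nn1`: 71.3%
compound 2 `COc1ccc(-c2cc3ccc(OCCCCCn4cc(CNC(=O)CCCCC5CCSS5)nn4)cc3oc2=O)cc1OC`: 50.5%

In a functional assay on PC-12 cells (Rattus norvegicus) for cytotoxicity, read by MTT assay, with stated times of 3 h and 2 h, tested at 10 uM (on this read-out lower numbers stand for a weaker effect and higher numbers for a stronger effect at the one concentration tested), compound 1 gives 71.3% while compound 2 gives 50.5%. Compound 2 stands lowest of the two numbers, with the nearest number above it by a number 20.8 percentage points lower from compound 1 to compound 2 (beyond the scatter). Compound 3 `O=C(CCCCC1CCSS1)NCc1cn(CCCCCOc2ccc3cc(-c4ccc(Cl)c(Cl)c4)c(=O)oc3c2)nn1` is not yet measured; it differs from compound 2 as follows: 3,4-dichlorophenyl in place of 3,4-dimethoxyphenyl on an aromatic carbon. For the measured compounds named here, the single measured step, a number 20.8 percentage points lower from compound 1 to compound 2 (beyond the scatter), covers 3,4-dimethoxyphenyl in place of hydrogen, not an exchange of one aryl for another, so it bears only loosely here. Going by the values given here, no step shows 3,4-dichlorophenyl. A step of a number 4.5 percentage points higher from compound 2 to compound 3 (within the scatter) is therefore expected, essentially none beyond the scatter. Compound 3 is estimated at 55%, range 35% to 75%.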

Compound 3, a percentage reported as activity, at one concentration (the size of the read-out at that concentration, not a potency): 59.4%
The estimate for compound 3 lay 4.4 percentage points below the measured number; low and high end bracket the measured number.
By their numbers in this assay, from the lowest: compounds 2 and 3 (each within the scatter of the next); then compound 1.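

In this assay the exchange of 3,4-dimethoxyphenyl for 3,4-dichlorophenyl gives a number 8.9 percentage points higher from compound 2 to compound 3 (within the scatter), so this aromatic carbon does not separate these two aryl groups, though only one carries hydrogen-bond acceptors. Against hydrogen, 3,4-dichlorophenyl gives a number 11.9 percentage points lower from compound 1 to compound 3 (beyond the scatter), so a change beyond the scatter now holds for two aryl groups rather than one. No measurement at hand accounts for this. Still open, from the compounds shown here alone, is how an unsubstituted phenyl, or a phenyl carrying a carboxylic acid or an amine, would read at this carbon.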